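The source may hold more compounds than are shown below. What is called first, only, known or untested is meant among the compounds shown, and "the series" means these compounds.

Measured compounds:

- compound 1, `Cc1cc(/C=C/c2ccc(O)cc2)[nH]n1`: 48100 nM
- compound 2, `COc1ccc(/C=C/c2cc(C)n[nH]2)cc1`: 8900 nM
- compound 3, `COc1ccc(/C=C/C(=O)CC(C)=O)cc1`: 15800 nM

In a functional assay on PC-3 cells (Homo sapiens) for cytotoxicity, read by MTT assay, with a stated time of 72 h (on this read-out lower numbers stand for stronger inhibition and higher numbers for weaker inhibition), compound 2 gives 8900 nM, while compound 1 gives 48100 nM. Among the measured compounds shown here, the only step measured within one scaffold is a 5.4-fold higher number from compound 2 to compound 1 (0.73 log units; beyond the scatter), and the change behind it is hydrogen in place of methyl on an oxygen on an aromatic ring. Compound 3 gives 15800 nM in this assay; its value and that of compound 2 lie within the scatter of each other, so nothing is read into their order. The difference between the two cores of compound 2 and compound 3 is not broken down here.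

Compound 4, `CC(=O)CC(=O)/C=C/c1ccc(O)cc1`, is not yet measured in this assay. For the measured compounds named here, it differs from compound 3 by hydrogen in place of methyl on an oxygen on an aromatic ring, which is the same change, at the same kind of place, as the one between compound 2 and compound 1. Among the compounds shown this change occurs twice in all, and only one instance is measured, so the expectation rests on a single step.

Going by the values given here, for this assay the step from compound 3 to compound 4 is expected to be a 5.1-fold higher number from compound 3 to compound 4 (0.70 log units; beyond the scatter), a size taken from the earlier instance because a 5.4-fold higher number from compound 2 to compound 1 (0.73 log units; beyond the scatter) is the only measured example of this change. From the compounds shown here alone, compound 4 is accordingly expected to give about 80000 nM, with a plausible span from 30000 nM to 200000 nM, the width reflecting that the transfer between two different cores is untested.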

Compound 4, half-maximal inhibitory concentration: 20200 nM
Beside the measured number, compound 4's estimate is 4.0-fold (0.60 log units) above it; the measured number lies below the stated range.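

In this assay, the change from methoxy to hydroxy gives a 1.3-fold higher number from compound 3 to compound 4 (0.11 log units; within the scatter). On this core the change therefore has no effect that can be read, and the size of the step measured on the other core did not carry over. The two instances of the same change do not agree: the same change on two cores in this assay, a 5.4-fold higher number (0.73 log units; beyond the scatter) from compound 2 to compound 1 and a 1.3-fold higher number (0.11 log units; within the scatter) from compound 3 to compound 4, 4.2-fold (0.63 log units) apart, beyond the scatter of two such steps Within this series, then, the size of the step cannot be taken from one of these two cores to the other, but two steps on two cores give no rule for a third core and do not identify which feature of the cores goes with the difference.

The compounds shown carry only methoxy or hydroxy on an oxygen on an aromatic ring, so it remains open whether an ethoxy group, or an amine or a fluorine atom in place of that oxygen group, would also give steps that differ between the two cores. Also open, from the compounds shown here alone, is whether a longer chain in place of the methyl group on each core would bring the two steps closer together or move them further apart.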